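The source may hold more compounds than are shown below. What is called first, only, known or untested is meant among the compounds shown, and "the series" means these compounds.

Measured so far:
- compound 1 `COc1ccc(/C=N\NC(=S)NC(C)(C)CCC[C@](C)(O)[C@@H]2CC=C(C)CC2)cc1`: 7420 nM
- compound 2 `CC1=CC[C@@H]([C@@](C)(O)CCCC(C)(C)NC(=S)N/N=C\c2ccc([N+](=O)[O-])cc2)CC1`: 12300 nM

Going by the values given here, in a functional assay on HT-29 cells (Homo sapiens) for cytotoxicity, read by sulforhodamine B assay (on this read-out higher numbers stand for weaker inhibition of growth and lower numbers for stronger inhibition of growth), compound 1 stands level with compound 2, the only other measured compound: a 1.7-fold higher number from compound 1 to compound 2 (0.22 log units; within the scatter). Compound 3 `CC1=CC[C@@H]([C@@](C)(O)CCCC(C)(C)NC(=S)N/N=C\c2cccc(Cl)c2)CC1` differs from compound 1 as follows: 3-chlorophenyl in place of 4-methoxyphenyl on a carbon with a double bond to nitrogen. That is 3-chlorophenyl in place of 4-methoxyphenyl on a carbon with a double bond to nitrogen. Among the compounds with values here, the one measured step bearing on this is nitro in place of methoxy on an aromatic carbon, and no measured compound carries chlorine. No change beyond the scatter is therefore expected in this assay. The expected step is a 1.1-fold higher number from compound 1 to compound 3 (0.03 log units; within the scatter). The estimate for compound 3 is 8000 nM, with an expected range of 3500 nM to 17000 nM.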

Compound 3, concentration for 50% growth inhibition: 6890 nM
Beside the measured number, compound 3's estimate is 1.2-fold (0.06 log units) above it; measured number inside the range.
By their numbers in this assay, from the lowest: compounds 3, 1 and 2 (each within the scatter of the next).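

In this assay, replacing 4-methoxyphenyl with 3-chlorophenyl on the carbon with a double bond to nitrogen gives a 1.1-fold lower number from compound 1 to compound 3 (0.03 log units; within the scatter), and replacing 4-nitrophenyl gives a 1.8-fold lower number from compound 2 to compound 3 (0.25 log units; within the scatter). The three aryl groups therefore cannot be separated at this position, and a chlorine-bearing ring stays level with the methoxy- and nitro-bearing rings. No evidence on hand bears on this result.

Going by these compounds, whether 4-chlorophenyl, unsubstituted phenyl or a pyridine ring would stay level in this assay remains open. So does the outcome with an amine on the ring.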